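Anilide substituent exchange, bromo to nitro: cytotoxicity outlook

The source may hold more compounds than are shown below. What is called first, only, known or untested is meant among the compounds shown, and "the series" means these compounds.

Compound 2 `Cc1cc(C#N)cc(C)c1Oc1ccnc(S(=O)(=O)CC(=O)Nc2ccc(Br)cc2)n1` is one of two members of the series measured in an ADME assay on MT4 cells (Homo sapiens) for cytotoxicity, read by MTT assay, with a stated time of 4 days; a lower number here means that less compound is tolerated, a higher number that more compound is tolerated. Compound 2 gives 15600 nM, the lowest of the two numbers, while compound 1 `Cc1cccc(NC(=O)CS(=O)(=O)c2nccc(Oc3c(C)cc(C#N)cc3C)n2)c1` gives 25700 nM. Among the compounds with values here, the single measured step between them, a 1.6-fold lower number from compound 1 to compound 2 (0.22 log units; within the scatter), stays within the scatter. Compound 3 `Cc1cc(C#N)cc(C)c1Oc1ccnc(S(=O)(=O)CC(=O)Nc2ccc([N+](=O)[O-])cc2)n1` is not yet measured in this assay. Its difference from compound 2 is nitro in place of bromo on an aromatic carbon. Within the data shown here, only one measured step bears on this change, and only loosely: it also exchanged a group on the amide-type nitrogen and moved the number by an amount within the scatter. Among the measured compounds shown here, nothing measured so far separates itself from the scatter, so no shift beyond it is expected in this assay for compound 3. Compound 3 is estimated at 15000 nM, with a range from 6000 nM to 40000 nM. The expected step is a 1.0-fold lower number from compound 2 to compound 3 (0.02 log units; within the scatter).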

Compound 3, half-maximal cytotoxic concentration: 59600 nM
Compound 3: the middle estimate sits 4.0-fold (0.60 log units) below what was measured; measured number outside the range, above it.
By their numbers in this assay, from the lowest: compounds 2 and 1 (each within the scatter of the next); then compound 3.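

Nitro in place of bromo, on an aromatic carbon para to a large group, gives a 3.8-fold higher number from compound 2 to compound 3 (0.58 log units; beyond the scatter) in this assay, so this position of the anilide ring can move the number beyond the scatter, which a 1.6-fold lower number from compound 1 to compound 2 (0.22 log units; within the scatter) did not show. The comparison with the 3-methylphenyl anilide points the same way, with 4-nitrophenyl in place of 3-methylphenyl giving a 2.3-fold higher number from compound 1 to compound 3 (0.37 log units; beyond the scatter) and leaving compound 3 apart from both other compounds, as the one tolerated at the highest concentration. The data at hand offer no measurement that accounts for this step.

On these data alone, whether the higher number is particular to nitro or is shared by other groups at this position, such as an amine or a carboxylic acid, remains open. Also open, as far as these compounds go, is whether nitro would give a similar step elsewhere on the same ring.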